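Methoxy step from compound 3 to compound 4

A few compounds are considered here, and "the series" means these few. Any claim that something is new, unique, unknown or untested is made for them only; others in the source may bear on it.

Measured in a functional assay on U-373MG ATCC cells for inhibition, with U373 MG (Homo sapiens) as the target, read by MTT assay, with a stated time of 7 days; on this read-out lower numbers stand for stronger inhibition of growth and higher numbers for weaker inhibition of growth:
- compound 1 `NC(=O)c1ncn2c(=O)n(Cc3ccccc3)nnc12`: > 50000 nM (a limit)
- compound 2 `COc1ccc(Cn2nnc3c(C(N)=O)ncn3c2=O)cc1`: > 50000 nM (a limit)
- compound 3 `C[C@H](c1ccccc1)n1nnc2c(C(N)=O)ncn2c1=O`: > 50000 nM (a limit)

Compound 3 stands at > 50000 nM, which is a limit and not a number. The measured set offers only (the limit of > 50000 nM in this assay, at which 3 of the 3 values shown sit), so no order among the compounds can be read from it.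

Next in line is compound 4 `COc1ccc([C@@H](C)n2nnc3c(C(N)=O)ncn3c2=O)cc1`. The change is methoxy in place of hydrogen on an aromatic carbon, para to a large group. The same replacement has been measured once, as a step that the two limits leave unreadable from compound 1 to compound 2. The other measured change, a step that the two limits leave unreadable from compound 1 to compound 3, brings in the methyl group that compound 4 also carries. Neither step has a size to carry over, so no direction is expected and no step beyond the scatter is foreseen. Another limit is the likeliest report. The expected step is a number no higher from compound 3 to compound 4 (the limit leaves the size open). For compound 4 the estimated value is 50000 nM, with an expected range from 20000 nM to 100000 nM.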

Compound 4, concentration for 50% growth inhibition: > 50000 nM
Compound 4: no number, only a limit; the forecaster's own chance of this, stated with the estimate: 85%; the middle value lies on the limit itself.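

Compound 4 gives > 50000 nM in this assay, which is a limit and not a number. The steps to compound 4 from compound 3 and from compound 2 therefore cannot be read. The compounds shown leave open whether either change on the shared core alters growth inhibition, since all share one limit: the limit of > 50000 nM in this assay, at which 4 of the 4 values shown sit.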